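The source may report more compounds than this note shows. Statements on the series, on what has been measured and on what is new or still open speak of the compounds shown alone.

Measured in a functional assay on HepG2 cells (Homo sapiens) for cytotoxicity, read by MTT assay, with a stated time of 48 h; on this read-out lower numbers stand for stronger inhibition and higher numbers for weaker inhibition:
compound 1 `CCCCCCCCCCCCNC(=O)[C@@H](NC(=O)c1nccc2ccccc12)[C@@H](C)O` — 65700 nM
compound 2 `CCCCCCCCCCCCCCNC(=O)[C@@H](NC(=O)c1nccc2ccccc12)[C@@H](C)O` — 28600 nM
compound 3 `CCCCCCCCCCCCCCCCCCNC(=O)[C@@H](NC(=O)c1ccco1)[C@@H](C)O` — 42300 nM

Compound 3 stands second highest of the three, and its gaps to compound 2 and to compound 1 both lie within the scatter. Compound 4 `CCCCCCCCCCCCCCCCCCNC(=O)[C@@H](NC(=O)c1nccc2ccccc12)[C@@H](C)O` differs from compound 3 by isoquinolin-1-yl in place of furan-2-yl on a carbonyl carbon. No measured step repeats this ring exchange; the only step shown, a 2.3-fold lower number from compound 1 to compound 2 (0.36 log units; beyond the scatter), concerns chain length, not the aromatic group. Compound 4 pairs the isoquinolin-1-yl of compounds 1 and 2 with the octadecyl chain of compound 3. Since compound 2 and compound 3 sit within the scatter of each other, only a small step is expected in this assay, tending lower. Compound 4 is estimated at 25000 nM (range 9000 nM to 60000 nM), corresponding to an expected 1.7-fold lower number from compound 3 to compound 4 (0.23 log units; within the scatter).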

Compound 4, half-maximal inhibitory concentration: 96900 nM
Compound 4: middle estimate off by 3.9-fold (0.59 log units), on the low side; the whole stated range lies below it.
By their numbers in this assay, from the lowest: compounds 2, 3, 1 and 4 (each within the scatter of the next, the first and the last beyond it).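

In this assay the exchange of furan-2-yl for isoquinolin-1-yl on a carbonyl carbon, with the octadecyl chain held, gives a 2.3-fold higher number from compound 3 to compound 4 (0.36 log units; beyond the scatter) and so is not neutral at this position. The chain trend also turns: a 2.3-fold lower number from compound 1 to compound 2 (0.36 log units; beyond the scatter) is followed by a 3.4-fold higher number from compound 2 to compound 4 (0.53 log units; beyond the scatter) on further lengthening, while a 1.5-fold higher number from compound 1 to compound 4 (0.17 log units; within the scatter) leaves the two ends of this set unseparated, so compound 2 alone stands apart among the isoquinolin-1-yl compounds. No evidence on the origin of either result is available.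

As far as these compounds go, whether the ring exchange gives a step of the same size on a shorter chain remains open. So does the reading of a phenyl group on this carbonyl, or of a chain ending in an amine.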